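The source may hold more compounds than are shown below. What is called first, only, known or untested is meant among the compounds shown, and "the series" means these compounds.

In a functional assay on U-251 cells (Homo sapiens) (a lower number here means a stronger inhibitor of growth, a higher number a weaker inhibitor of growth), two compounds with a shared core have been measured so far. Compound 1 `O=S(=O)(/C=C/c1ccc(Cl)cc1Cl)Cc1ccc(Nc2ncnc3cc(Cl)ccc23)cc1` gives 53000 nM. Compound 2 `O=S(=O)(/C=C/c1ccc(C(F)(F)F)cc1F)Cc1ccc(Nc2ncnc3cc(Cl)ccc23)cc1` stands only at a limit, > 100000 nM. The next compound is compound 3 `O=S(=O)(/C=C/c1ccc(F)cc1Cl)Cc1ccc(Nc2ncnc3cc(Cl)ccc23)cc1`, which has 2-chloro-4-fluorophenyl in place of 2-fluoro-4-(trifluoromethyl)phenyl on a double-bonded chain carbon bound to a double-bonded chain carbon. Within the data shown here, one measured step bears on this change, at the same place: an at least 1.8-fold higher number from compound 1 to compound 2 (0.27 log units; that floor lies within the scatter). That step gives only a floor, so it fixes no size for a change at this place. The closest guide is compound 1 at 53000 nM, whose 2,4-dichlorophenyl group, like the group entering compound 3, carries chlorine and no trifluoromethyl. In this assay, a modest move towards a lower number is therefore expected, of a size that may not clear the scatter. The estimated change is an at least 1.6-fold lower number from compound 2 to compound 3 (0.22 log units; that floor lies within the scatter). Compound 3 is expected at 60000 nM, with an estimated range of 30000 nM to 100000 nM.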

Compound 3, concentration for 50% growth inhibition: 2000 nM
Compound 3: the middle estimate sits 30-fold (1.48 log units) above what was measured; measured number below the stated range.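

In this assay, fluoro in place of chloro on an aromatic carbon gives a 27-fold lower number from compound 1 to compound 3 (1.42 log units; beyond the scatter), so exchanging a single halogen at this place moves the number by a large step, which the earlier pair, resting on a floor within the scatter, could not show. Placing 2-chloro-4-fluorophenyl where 2-fluoro-4-(trifluoromethyl)phenyl stood gives an at least 50-fold lower number from compound 2 to compound 3 (1.69 log units; beyond the scatter), the first change at this place to lie beyond the scatter, and with both steps beyond the scatter compound 3 is the most potent of the three. That step is still only a floor, and its true size stays unknown, as compound 2 gives a limit rather than a number: the limit of > 100000 nM in this assay, at which 1 of the 3 values shown sits.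

The compounds shown leave open whether the large step belongs to fluoro alone or depends on the chloro that compound 1 and compound 3 share on the same aromatic group. They also leave open how a methoxy group, a nitrile or an amine on that aromatic carbon would read in this assay.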